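The source may hold more compounds than are shown below. What is called first, only, known or untested is meant among the compounds shown, and "the series" means these compounds.

Series notes. Compound 1 `O=c1ccn(CCCCCOc2ccc([N+](=O)[O-])cc2)c(=O)[nH]1` and compound 2 `O=c1ccn(CCCCOc2ccc(Br)cc2)c(=O)[nH]1` belong to the same set but carry no result in an ADME assay on HEL cells (Homo sapiens) for cytotoxicity; a lower number here means that less compound is tolerated, a higher number that more compound is tolerated: for compound 1 the entry reads "not determined" (no result reported), and for compound 2 the entry reads "not determined" (no result reported). Among the compounds with values here, compound 3 `N#Cc1ccc(OCCCCCn2ccc(=O)[nH]c2=O)cc1` is the one member with a number: in this assay compound 3 gives 100000 nM, and it stands alone, since no second value exists to set beside it. Within the data shown here, no step between measured compounds can be read from this set.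

Compound 4 `O=c1ccn(CCCCCOc2ccccc2)c(=O)[nH]1` is still to be measured in this assay. The change from compound 3 to compound 4 is hydrogen in place of cyano on an aromatic carbon, the rest of the molecule untouched.

With only compound 3 as anchor, the expectation for compound 4 rests on that single value. The step from compound 3 to compound 4 is expected to stay within the usual scatter, with no direction favoured: no change at the digits printed from compound 3 to compound 4 (within the scatter). Compound 4 is therefore expected to give about 100000 nM in this assay, with a range from 50000 nM to 200000 nM, noting that a result at this level may also come back as a limit rather than a number.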

Compound 4, half-maximal cytotoxic concentration: > 100000 nM
Compound 4 was reported as a limit; the forecaster's own chance of this, stated with the estimate: 40%; the middle value lies on the limit itself.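

Within the data shown here, this is the first comparison the series allows at this place, on an aromatic carbon para to a large group: hydrogen in place of cyano gives a number no lower from compound 3 to compound 4 (the limit leaves the size open) in this assay. Compound 4 gives > 100000 nM, which is a limit and not a number. The cyano group is therefore not needed for the compound to be tolerated at the level reached here, and the size of the step stays bounded by the assay's limit: the limit of > 100000 nM in this assay, at which 1 of the 4 values shown sits.

As far as these compounds go, whether an amine or a carboxylic acid at this place would bring a number within the range of this assay remains open. The compounds shown also leave open how a longer chain between the core and the aromatic ring would read, and compound 1 and compound 2 add nothing, as neither has a reported result.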